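Working notes: from compound 1 to compound 3

The compounds below may be only part of what the source reports. "The series", "measured", "known", "first", "only" and "open" are said of these compounds alone.

In an ADME assay on HEp-2 cells (Homo sapiens) for cytotoxicity (on this read-out lower numbers stand for higher toxicity in this test and higher numbers for lower toxicity in this test), compound 1 (`C=C(C)n1c(=O)n(Cc2nc3ccccc3n2CCC(C)C)c2ccccc21`) gives 24600 nM and is the higher of the two measured compounds. Compound 2 (`CC(C)CCn1c(Cn2c(=O)n(C(C)C)c3ccccc32)nc2c(CN)cccc21`) gives 7000 nM in this assay and lies lower by more than the scatter. Compound 3 (`C=C(C)n1c(=O)n(Cc2nc3cc(C(=N)N)ccc3n2CCC(C)C)c2ccccc21`) differs from compound 1 by a group of 3 heavy atoms (1 carbon, 2 nitrogen; no ring) in place of a hydrogen atom, on an aromatic carbon on an aromatic carbon of a six-membered aromatic ring of carbon only. Among the measured compounds shown here, no measured step covers this change, so the expectation rests only on the gap between these two values. A modest fall is expected, with an estimated 1.8-fold lower number from compound 1 to compound 3 (0.24 log units; within the scatter) in this assay overall. For compound 3 the estimated value is 14000 nM within an expected range of 4000 nM to 50000 nM for now.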

Compound 3, half-maximal cytotoxic concentration: 10800 nM
The estimate for compound 3 lay 1.3-fold (0.11 log units) above the measured number; low and high end bracket the measured number.
By their numbers in this assay, from the lowest: compounds 2 and 3 (each within the scatter of the next); then compound 1.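

In this assay, a group of 3 heavy atoms (1 carbon, 2 nitrogen; no ring) in place of a hydrogen atom on this aromatic carbon gives a 2.3-fold lower number from compound 1 to compound 3 (0.36 log units; beyond the scatter). This is the only single-place change shown, and it marks this position as one where substitution moves the read-out beyond the scatter. Nothing available explains the shift.

Going by these compounds, it remains open whether the shift belongs to this group or to substitution at this carbon generally. A nitrile, an amine or a carboxylic acid at the same place would separate the two readings.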